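Methyl on the phenyl of compound 1: expected cytotoxicity

The source may hold more compounds than are shown below. What is called first, only, known or untested is meant among the compounds shown, and "the series" means these compounds.

Measured in a functional assay on C6 cells (Rattus norvegicus) for cytotoxicity, read by MTT assay, with a stated time of 24 h, tested at 200 ug/mL; a higher number here means a weaker effect of the compound at the concentration tested, a lower number a stronger effect:
compound 1, `Cc1nnc(SCC(=O)N/N=c2/scc(-c3ccccc3)n2-c2ccccc2)s1`, 59.2%
compound 2, `Cn1nnnc1SCC(=O)N/N=c1/scc(-c2ccc(C#N)cc2)n1-c1ccccc1`, 28.6%
compound 3, `O=C(CSc1nnnn1-c1ccccc1)N/N=c1/scc(-c2ccccc2)n1-c1ccccc1`, 22.6%

Compound 1 stands highest of the three numbers in this assay; compound 2 lies nearest to it and compound 3 furthest, both beyond the scatter. For the measured compounds named here, the one single-site step, a number 36.6 percentage points lower from compound 1 to compound 3 (beyond the scatter), concerns the group on the sulfur and was large. Compound 2 differs from compound 1 in two places, so its values show only that it lies well below compound 1.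

Compound 4, `Cc1ccc(-c2cs/c(=N/NC(=O)CSc3nnc(C)s3)n2-c2ccccc2)cc1`, is not yet measured. It differs from compound 1 by methyl in place of hydrogen on an aromatic carbon, the aromatic carbon sitting para to a large group. Going by the values given here, no measured step touches this ring at all, so nothing here speaks to a change at that position, and a step within the scatter is the plain expectation. Compound 4 is therefore expected to give 58% in this assay, within 40% to 76%, meaning an expected step of a number 1.2 percentage points lower from compound 1 to compound 4 (within the scatter).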

Compound 4, a percentage reported as activity, at one concentration (the size of the read-out at that concentration, not a potency): 13.3%
The estimate for compound 4 lay 44.7 percentage points above the measured number; the whole stated range lies above it.
By their numbers in this assay, from the lowest: compounds 4, 3 and 2 (each within the scatter of the next, the first and the last beyond it); then compound 1.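

In this assay the change from phenyl to 4-methylphenyl gives a number 45.9 percentage points lower from compound 1 to compound 4 (beyond the scatter) and so shows that this ring, unchanged in the earlier single-site comparison, is not silent: methyl in place of hydrogen on an aromatic carbon, para to a large group, is enough for a large step. The earlier step of a number 36.6 percentage points lower from compound 1 to compound 3 (beyond the scatter) concerned only the group on the sulfur, so compound 1 now has a large step at each of two separate sites. Nothing at hand bears on the origin of the methyl step.

On these data alone, whether this step belongs to methyl itself or to any group on that carbon stays open; a chlorine, an amine, a carboxylic acid or a longer chain such as ethyl there would test it. Also open, as far as these compounds go, is whether the methyl step carries over to compounds with 1-phenyl-1H-tetrazol-5-yl on the sulfur.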